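A few compounds are considered here, and "the series" means these few. Any claim that something is new, unique, unknown or untested is made for them only; others in the source may bear on it.

Three compounds share one core and were tested in a functional assay on T47D cells (Homo sapiens) for activation; a lower number here means that less compound is needed, a higher number that more compound is needed for the effect. Compound 1 `COc1cc(C2C(C#N)=C(N)Oc3cc(Br)ccc32)cc(Br)c1OC` gives 140000000 nM, compound 2 `COc1cc(C2C(C#N)=C(N)Oc3cc(O)ccc32)cc(Br)c1OC` gives 130000000 nM, and compound 3 `COc1ccc2c(c1)OC(N)=C(C#N)C2c1cc(Br)c(OC)c(OC)c1` gives 17000000 nM, the lowest of the three numbers; the steps of an 8.2-fold lower number from compound 1 to compound 3 (0.92 log units; beyond the scatter) and a 7.6-fold lower number from compound 2 to compound 3 (0.88 log units; beyond the scatter) both lie beyond the scatter, whereas a 1.1-fold lower number from compound 1 to compound 2 (0.03 log units; within the scatter) stays within it. Compound 4 `COc1cc(C2C(C#N)=C(N)Oc3cc(Cl)ccc32)cc(Br)c1OC` differs from compound 3 by chloro in place of methoxy on an aromatic carbon. The bromo analogue, compound 1, is the nearest guide, because an 8.2-fold lower number from compound 1 to compound 3 (0.92 log units; beyond the scatter) shows a halogen in that place giving the higher number, so a modest rise is expected for compound 4, namely a 5.9-fold higher number from compound 3 to compound 4 (0.77 log units; beyond the scatter). Compound 4 is therefore estimated to give 100000000 nM, with a range from 30000000 nM to 300000000 nM.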

Compound 4, half-maximal effective concentration: 160000000 nM
Beside the measured number, compound 4's estimate is 1.6-fold (0.20 log units) below it; measured number inside the range.
By their numbers in this assay, from the lowest: compound 3; then compounds 2, 1 and 4 (each within the scatter of the next).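

At this position on the ring carrying the fused system, methoxy alone stands apart in this assay: changing it to chloro gives a clear rise (a 9.4-fold higher number from compound 3 to compound 4 (0.97 log units; beyond the scatter)). Chloro, bromo and hydroxy cannot be told apart (a 1.1-fold higher number from compound 1 to compound 4 (0.06 log units; within the scatter); a 1.2-fold higher number from compound 2 to compound 4 (0.09 log units; within the scatter)), so chloro joins the two groups already seen to match each other. No data here explain what sets methoxy apart. Still open, as far as these compounds go, is whether an ethoxy, an amine or a carboxylic acid at this position would fall with methoxy or with the other three groups.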